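The source may hold more compounds than are shown below. What is called first, only, known or untested is meant among the compounds shown, and "the series" means these compounds.

In an ADME assay on HEK293 cells (Homo sapiens) for cytotoxicity, read by ATP content, with a stated time of 6 h (on this read-out lower numbers stand for higher toxicity in this test and higher numbers for lower toxicity in this test), compound 1 (`CCCCNc1nc(N)nc2ccn(Cc3nccs3)c12`) gives > 24000 nM as a limit of the assay and not a number. In this assay compound 2 (`COCCNc1nc(N)nc2ccn(Cc3ccccn3)c12`) gives > 24000 nM as a limit too, so its standing is known only as a limit and not as a number. Among the measured compounds shown here, the series so far comes down to the limit of > 24000 nM in this assay, at which 2 of the 2 values shown sit, and holds no step between measured compounds. The change from compound 2 to compound 3 (`CCOCCNc1nc(N)nc2ccn(Cc3ccccn3)c12`) is methyl in place of hydrogen on a saturated chain carbon bound to an oxygen on a saturated carbon and reads methoxy to ethoxy. With compound 2 known only as a limit, no step beyond the usual scatter is expected in this assay and a further limit is the likeliest report. The estimated step is a step that the limit leaves unreadable from compound 2 to compound 3 and it remains only an expectation. For compound 3 the estimated value is 26000 nM with an expected range from 14000 nM to 48000 nM and a report as a limit is expected to be more likely than a number.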

Compound 3, half-maximal cytotoxic concentration: > 24000 nM
Compound 3 ended at the assay's limit (the forecaster's own chance of this, stated with the estimate: 85%); the middle value does not contradict the limit.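

In this assay compound 2 and compound 3 both stand at a limit of the assay and not at a number, so no step can be read for methoxy to ethoxy. The compounds shown leave open whether any change in structure moves this read-out at all: the limit of > 24000 nM in this assay, at which 3 of the 3 values shown sit.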